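The source may report more compounds than this note shows. Statements on the series, on what has been measured and on what is new or still open speak of the compounds shown alone.

Measured so far in an assay on isolated protein for inhibition of Nicotinamide phosphoribosyltransferase (Homo sapiens), read by mass spectrometry, with stated times of 15 min and 30 min; on this read-out higher numbers stand for weaker inhibition and lower numbers for stronger inhibition:
compound 1 `CCCn1cc(S(=O)(=O)c2ccc(CNC(=O)N3Cc4ccncc4C3)cc2)cn1` gives 17 nM.
compound 2 `CC(=O)N1CCC(S(=O)(=O)c2ccc(CNC(=O)N3Cc4ccncc4C3)cc2)CC1` gives 83 nM.
compound 3 `O=C(NCc1ccc(S(=O)(=O)N2CCC[C@H](O)C2)cc1)N1Cc2ccncc2C1` gives 770 nM.

Compound 3 has the highest number of the three, that is, it is the weakest inhibitor here. Both steps leading to it go the same way: a 45-fold higher number from compound 1 to compound 3 (1.66 log units; beyond the scatter) and a 9.3-fold higher number from compound 2 to compound 3 (0.97 log units; beyond the scatter). Compound 3 is the only one of the three in which the group on the sulfonyl sulfur is joined through a ring nitrogen rather than a ring carbon.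

Compound 4 `CN1CCN(S(=O)(=O)c2ccc(CNC(=O)N3Cc4ccncc4C3)cc2)CC1` has not yet been measured. It differs from compound 3 in one place: 4-methylpiperazin-1-yl in place of 3-hydroxypiperidin-1-yl on a sulfonyl sulfur. For the measured compounds named here, no measured step swaps one such nitrogen-joined ring for another, so nothing directly tells how much this exchange matters. Going by the values given here, what the data do show is that compound 3, the one existing example of this kind of attachment, sits far from compounds 1 and 2, and compound 4 keeps that kind of attachment. The expectation is therefore a number close to that of compound 3, with no step beyond the usual scatter, expressed as a 1.1-fold lower number from compound 3 to compound 4 (0.04 log units; within the scatter). The estimate for compound 4 in this assay is 700 nM, expected to lie between 250 nM and 2500 nM.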

Compound 4, half-maximal inhibitory concentration: 38 nM
Compound 4: the middle estimate sits 18-fold (1.27 log units) above what was measured; the whole stated range lies above it.
By their numbers in this assay, from the lowest: compound 1; then compound 4; then compound 2; then compound 3.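

In this assay, joining the group to the sulfonyl sulfur through a ring nitrogen does not in itself go with a high number, since two six-membered non-aromatic rings attached in this same way and of equal heavy-atom count are far apart (a 20-fold lower number from compound 3 to compound 4 (1.31 log units; beyond the scatter)). This large step shows that the position responds strongly to the make-up of the ring, not only to the atom that joins it to the sulfur, and compound 4 falls among the groups joined through a ring carbon (a 2.2-fold lower number from compound 2 to compound 4 (0.34 log units; beyond the scatter); a 2.2-fold higher number from compound 1 to compound 4 (0.35 log units; beyond the scatter)), both modest steps. The exchange replaces a ring with 1 hetero atom, 1 hydrogen-bond donor and 1 defined stereocentre by a ring with 2 hetero atoms and 0 hydrogen-bond donors, and nothing measured here tells which of these differences matters or why.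

The compounds shown do not separate these differences: plain piperidin-1-yl, with no hydroxyl, and morpholin-4-yl, with a ring oxygen in place of the methyl-bearing nitrogen, would each change only part of the exchange. Also open, on these data alone, is how much the methyl contributes, which piperazin-1-yl with a free amine or 4-ethylpiperazin-1-yl would address.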